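The compounds below may be only part of what the source reports. "The series", "measured", "known", "first", "only" and "open" are said of these compounds alone.

Compound 1 `COc1ccccc1N1CCN(CC(=O)N2CCN(c3nnc(-c4ccccc4)c(-c4ccccc4)n3)CC2)CC1` gives 444000 nM in an ADME assay on NIH3T3 cells (Mus musculus) for cytotoxicity, read by MTT assay, with a stated time of 24 h; on this read-out lower numbers stand for stronger inhibition and higher numbers for weaker inhibition. Compound 2 `O=C(CN1CCN(c2ccccc2Cl)CC1)N1CCN(c2nnc(-c3ccccc3)c(-c3ccccc3)n2)CC1` gives 350000 nM in this assay. Compound 3 `COc1cccc(N2CCN(CC(=O)N3CCN(c4nnc(-c5ccc(C)cc5)c(-c5ccc(C)cc5)n4)CC3)CC2)c1` reaches only a limit of the assay, > 866000 nM, in this assay.

The step from compound 1 to compound 2 is chloro in place of methoxy on an aromatic carbon; in this assay it gives a 1.3-fold lower number from compound 1 to compound 2 (0.10 log units; within the scatter). The difference between the core of compound 1 and the core of compound 3 is not broken down here. Compound 4 `Cc1ccc(-c2nnc(N3CCN(C(=O)CN4CCN(c5cccc(Cl)c5)CC4)CC3)nc2-c2ccc(C)cc2)cc1` differs from compound 3 by chloro in place of methoxy on an aromatic carbon. This is the same kind of change as that from compound 1 to compound 2, but not the same: there the chloro stands ortho to a large group, here meta to a large group. For compound 3 the value is a limit (the limit of > 866000 nM in this assay, at which 1 of the 3 values shown sits), so its position can only be placed at or beyond it. Because the earlier step of a 1.3-fold lower number from compound 1 to compound 2 (0.10 log units; within the scatter) stayed within the scatter, the step for compound 4 is expected to be small, a step that the limit leaves unreadable from compound 3 to compound 4. Compound 4 is thus estimated at 900000 nM in this assay, between 400000 nM and 2000000 nM, with a fair chance that the assay again reports only a limit.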

Compound 4, half-maximal inhibitory concentration: 859000 nM
Compound 4: the middle estimate sits 1.0-fold (0.02 log units) above what was measured, within the range that was stated.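

Compound 3 stands only at a limit of the assay, > 866000 nM, so the size of the step to compound 4 cannot be read: the limit of > 866000 nM in this assay, at which 1 of the 4 values shown sits. Chloro in place of methoxy gives a number no higher from compound 3 to compound 4 (the limit leaves the size open). Whether chloro in place of methoxy carries over unchanged from one core to the other therefore cannot be judged in this assay: the same change on two cores in this assay, a 1.3-fold lower number (0.10 log units; within the scatter) from compound 1 to compound 2 and a number no higher (the limit leaves the size open) from compound 3 to compound 4; the limit leaves it open whether they differ What remains is that, with 3-chlorophenyl where compound 3 has 3-methoxyphenyl, compound 4 gives a measured 859000 nM, and that the two pairs differ in the place of the chloro as well as in the core, so even a readable gap could not be assigned to the core alone.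

The compounds shown leave open how the number would respond to other groups on that aromatic ring, such as an amine or a carboxylic acid, or to a longer chain in the linker. They also leave open how 3-chlorophenyl would behave on the core of compound 1.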